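The compounds below may be only part of what the source reports. "The series", "measured", "known", "first", "only" and "open" are said of these compounds alone.

Measured so far in an assay on cells (Hepatocyte) for inhibition of glucokinase regulatory protein (Mus musculus), with stated times of 20 min and 40 min; on this read-out lower numbers stand for an effect already at smaller amounts and higher numbers for an effect only at larger amounts of compound:
- compound 1 `CC#C[C@H]1CN(S(=O)(=O)c2ccc(N)nc2)CCN1c1ccc(C(O)(CC#N)C(F)(F)F)cc1`: 219 nM
- compound 2 `CC#C[C@H]1CN(S(=O)(=O)c2ccc(N)nc2)CCN1c1ccc(C(O)(C(F)(F)F)C(F)(F)F)cn1`: 421 nM
- compound 3 `CC#C[C@H]1CN(S(=O)(=O)c2ccc(N)nc2)CCN1c1ncc(C(C)(O)C(F)(F)F)s1`: > 12500 nM

Compound 1 and compound 2 sit within the usual scatter of each other in this assay, so no order between them can be read from these two numbers. For compound 3 this assay reports only a limit, > 12500 nM (the limit of > 12500 nM in this assay, at which 1 of the 3 values shown sits), and not a number. For the measured compounds named here, no two of the three measured compounds differ in a single place, so no measured step is available to calibrate the change considered here.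

Compound 4 `CC#C[C@H]1CN(S(=O)(=O)c2ccc(N)nc2)CCN1c1ccc(S(C)(=N)=O)cc1` keeps the shared core of compound 1 and changes one group on the aromatic ring: a group of 4 heavy atoms (1 carbon, 1 nitrogen, 1 oxygen, 1 sulfur; no ring) in place of a group of 9 heavy atoms (4 carbon, 1 nitrogen, 1 oxygen, 3 fluorine; no ring), on an aromatic carbon. The group entering carries the same count of hydrogen-bond donors and acceptors as the group leaving, while the trifluoromethyl and the nitrile are lost. Going by the values given here, with no measured step of this kind among the three compounds, the expectation rests on compound 1 alone: a modest move toward higher numbers is expected, a 2.3-fold higher number from compound 1 to compound 4 (0.36 log units; beyond the scatter), though a step within the scatter is also plausible. Compound 4 is therefore estimated at 500 nM in this assay, with a likely range from 150 nM to 2000 nM.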

Compound 4, half-maximal effective concentration: 704 nM
Compound 4: the middle estimate sits 1.4-fold (0.15 log units) below what was measured; measured number inside the range.
By their numbers in this assay, from the lowest: compounds 1, 2 and 4 (each within the scatter of the next, the first and the last beyond it). At a limit, above all of these: compound 3.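

For the compounds shown here, the exchange on an aromatic carbon, para to a large group, gives a 3.2-fold higher number from compound 1 to compound 4 (0.51 log units; beyond the scatter) in this assay and is the first measured step in one place. The group of 9 heavy atoms, with its trifluoromethyl and nitrile, can therefore be replaced by a group of 4 heavy atoms with the same count of hydrogen-bond donors and acceptors, at the cost of only a modest step. Nothing measured here gives a reason for this step.

Still open, from the compounds shown here alone, is how much of the step goes with the loss of the trifluoromethyl and how much with the loss of the nitrile. Going by these compounds, it is also open how a methyl sulfone or a carboxylic acid on the same aromatic carbon would read.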